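A few compounds are considered here, and "the series" means these few. Any claim that something is new, unique, unknown or untested is made for them only; others in the source may bear on it.

Compound 1 `Nc1nc(N)c2c(-c3ccsc3)cn([C@@H]3O[C@H](CO)[C@@H](O)[C@H]3O)c2n1`: in a functional assay on K562 cells (Homo sapiens), read by MTT assay, with a stated time of 72 h (on this read-out higher numbers stand for weaker inhibition and lower numbers for stronger inhibition), compound 1 gives > 20000 nM, which is a limit of the assay.
Compound 2 `O=c1[nH]cnc2c1c(-c1ccoc1)cn2[C@@H]1O[C@H](CO)[C@@H](O)[C@H]1O`: in this assay compound 2 gives 14500 nM.
Compound 3 `Cc1ncnc2c1c(I)cn2[C@@H]1O[C@H](CO)[C@@H](O)[C@H]1O`: in this assay compound 3 gives > 20000 nM, again a limit.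

Compound 3 therefore stands at a limit in this assay and carries no number of its own; (the limit of > 20000 nM in this assay, at which 2 of the 3 values shown sit). Compound 4 `Cc1ncnc2c1c(-c1ccoc1)cn2[C@@H]1O[C@H](CO)[C@@H](O)[C@H]1O` differs from compound 3 by furan-3-yl in place of iodo on an aromatic carbon. No step between two measured compounds is shown that follows this change. The same furan-3-yl sits on a different core in compound 2, which gives 14500 nM, a weak inhibition. The step of an at least 1.3-fold lower number from compound 3 to compound 4 (0.12 log units; that floor lies within the scatter) is expected to be modest, toward stronger inhibition at most. Compound 4 is estimated at 15000 nM, with a range from 5000 nM to 40000 nM.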

Compound 4, half-maximal inhibitory concentration: > 20000 nM
Compound 4: only a limit was reported; the forecaster's own chance of this, stated with the estimate: 45%; middle value at least 1.3-fold (0.12 log units) from the limit.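

Compound 3 and compound 4 both stand at a limit in this assay, so no step can be read between them. The compounds shown leave open how far furan-3-yl in place of iodo shifts inhibition, because the values end at one ceiling: the limit of > 20000 nM in this assay, at which 3 of the 4 values shown sit.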